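Trading a Phenyl-Bearing Chain for an Ester Chain

The source may report more compounds than this note shows. Statements on the series, on what has been measured and on what is new or still open speak of the compounds shown alone.

Compound 1, `Nc1nc(O)c2c(n1)n(C1OC(CO)[C@@H](O)[C@H]1O)c(=O)n2C/C=C/c1ccccc1`, was tested in a functional assay (B cells) with Mus musculus as the target (on this read-out lower numbers stand for an effect already at smaller amounts and higher numbers for an effect only at larger amounts of compound), where it gives 103 uM. Among the three measured compounds this is the second highest number. Compound 2, `CCCn1c(=O)n(C2CCC(COC(C)=O)O2)c2nc(NC(C)=O)nc(O)c21`, gives 154 uM in this assay; the two numbers lie within the scatter of each other, so no order between compound 1 and compound 2 can be claimed. Compound 3, `C=CCn1c(=O)n(C2CN(CCCC)CC(CO)O2)c2nc(N)nc(O)c21`, gives 5 uM in this assay, a lower number than compound 1 by more than the scatter. Compound 3 differs from compound 1 in several places at once, so no single change can be tied to that gap.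

Compound 4, `CCOC(=O)Cn1c(=O)n(C2OC(CO)[C@@H](O)[C@H]2O)c2nc(N)nc(O)c21`, is not yet measured. It arises from compound 1 by one change: ethoxycarbonyl in place of 2-phenylethenyl on a saturated chain carbon bound to an aromatic nitrogen. Among the measured compounds shown here, no measured pair shows this change, so the data give no guide to its size or direction. The expected step is therefore a 1.2-fold higher number from compound 1 to compound 4 (0.07 log units; within the scatter), a step not beyond the scatter. Compound 4 is thus expected to give about 120 uM in this assay, within a range from 30 uM to 400 uM.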

Compound 4, concentration for half-maximal effect: 48 uM
Compound 4: the middle estimate sits 2.5-fold (0.40 log units) above what was measured; low and high end bracket the measured number.
By their numbers in this assay, from the lowest: compound 3; then compound 4; then compounds 1 and 2 (each within the scatter of the next).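

Among the compounds shown here, this is the first measured step at this position on the shared core: in this assay the swap gives a 2.1-fold lower number from compound 1 to compound 4 (0.33 log units; beyond the scatter) and so moves the number modestly downward, just past the usual scatter. At this saturated chain carbon bound to an aromatic nitrogen, the effect therefore does not depend on 2-phenylethenyl and its six-membered aromatic ring, as ethoxycarbonyl, with no ring and fewer heavy atoms, does somewhat better. No measurement available here explains why the number falls with this swap.

The compounds shown leave open whether the lower number comes from the ester itself or simply from losing the phenyl ring; a carboxylic acid or a primary amide on the same carbon would help separate the two. They also leave open whether this swap would shift the number the same way on another core.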